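The source may report more compounds than this note shows. Statements on the series, on what has been measured and on what is new or still open speak of the compounds shown alone.

Within the data shown here, in a functional assay on CHO cells (Cricetulus griseus) for inhibition, read by MTT assay, with a stated time of 96 h (on this read-out higher numbers stand for weaker inhibition and lower numbers for stronger inhibition), compound 1 `CC1([C@@H](OC(=O)c2ccc(F)c3ccccc23)C(N)=O)CO1` gives 7000 nM and compound 2 `Cc1ccc(C(=O)O[C@@H](C(N)=O)C2(C)CO2)c2ccccc12` gives 5000 nM, so compound 2 stands level with the only other compound measured. Compound 3 `Cc1ccc(C(=O)O[C@H](C(N)=O)C2(C)CO2)c2ccccc12` is the unmeasured partner of compound 2: the two compounds have the same atoms and bonds; at least one stereo element is drawn with a configuration in one of them and without one in the other: 1 of 2 stereo elements differ; a stereocentre at a saturated chain carbon is drawn R in compound 2 and S in compound 3. Put simply, a stereocentre at a saturated chain carbon is drawn R in compound 2 and S in compound 3. Among the measured compounds shown here, the only measured step, a 1.4-fold lower number from compound 1 to compound 2 (0.15 log units; within the scatter), swaps fluoro for methyl on an aromatic carbon and leaves this stereocentre as drawn. For the measured compounds named here, it therefore bears only indirectly on the new change, and no measured pair tests a change of configuration. With no evidence for a direction, no shift beyond the scatter is expected, although the uncertainty is wide. The expected step is a 1.4-fold higher number from compound 2 to compound 3 (0.15 log units; within the scatter). Compound 3 is estimated at 7000 nM, with an expected range from 2000 nM to 25000 nM.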

Compound 3, half-maximal inhibitory concentration: 6000 nM
Estimate against measurement, compound 3: 1.2-fold (0.07 log units) above; the range from low to high includes it.
By their numbers in this assay, from the lowest: compounds 2, 3 and 1 (each within the scatter of the next).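

Among these compounds, compounds 2 and 3 give the first direct look at the configuration of this saturated chain carbon: drawing it S instead of R gives a 1.2-fold higher number from compound 2 to compound 3 (0.08 log units; within the scatter) in this assay. For this one pair, then, inverting the centre leaves the number within the usual scatter, whereas the earlier step concerned only fluoro and methyl on an aromatic carbon. The reading of the pair carries one qualification, since the comparison rests on a drawing: the fact that one of compounds 2 and 3 is drawn with a defined configuration and the other without, at the place where they differ

The compounds shown leave open whether this result holds with fluoro on the aromatic carbon, as in compound 1, and what the second stereo element contributes. They also leave open whether a carboxylic acid or a nitrile in place of the amide would shift the number beyond the scatter or make this stereocentre matter.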